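Swapping a phenyl for a cyclohexyl on compound 1

This account rests on a few compounds, and the source may have more. Where it says the series, first, only, none or still open, it means among the compounds named here.

Compound 1 (`O=C(c1ccccc1)N1CCC(C(=O)N2N=CCC2c2ccccc2)CC1`) gives 4.4 in a physicochemical assay for lipophilicity, read by HPLC, measured as chromatographic lipophilicity, at pH 7.4 (a lower number here means a more polar compound, a higher number a more lipophilic compound), and sits level with compound 2 (`CC(C)C(=O)N1N=CCC1c1ccccc1`) at 4.4 on this scale. These two share the lowest reading of the three measured compounds, while compound 3 (`CC(C)(C)C(=O)N1N=CCC1C1CCCCC1`) reads 7.3 and lies above them, well beyond the scatter.

The unmeasured compound 4 (`O=C(C1CCCCC1)N1CCC(C(=O)N2N=CCC2c2ccccc2)CC1`) keeps all of compound 1 except one group, with cyclohexyl in place of phenyl on a carbonyl carbon. Among the compounds with values here, no measured pair shows this change alone. Within the data shown here, compound 3 is the only measured compound with a cyclohexyl, and its reading of 7.3 gives only a rough hint of direction, since it has no matching partner among the others.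

The expected step of a number 1.00 log units higher from compound 1 to compound 4 (beyond the scatter) is upward in this assay and moderate in size, beyond the scatter but well short of the full gap up to compound 3. For compound 4 the estimated value is 5.4 with an expected range from 4.8 to 6.2 on this scale.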

Compound 4, distribution coefficient: 5.4
For compound 4 middle estimate and measured number coincide at the digits printed; the measured number falls inside the stated range.
By their numbers in this assay, from the lowest: compounds 1 and 2 (each within the scatter of the next); then compound 4; then compound 3.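

In this assay, the swap of phenyl for cyclohexyl on a carbonyl carbon can now be read alone: it gives a number 1.00 log units higher from compound 1 to compound 4 (beyond the scatter) and nothing else in the molecule differs. The two groups match in what is counted here, with 6 carbon heavy atoms each, no hydrogen-bond donors or acceptors and no net charge, so the step goes with one six-membered aromatic ring giving way to a non-aromatic one. What lies behind the step cannot be told, since no outside measurement bears on it.

Going by these compounds, this is a single swap at a single place, so whether it gives a step of similar size on another compound stays open. Also open, on these data alone, is how this assay would read with a longer chain or a group carrying an amine or a carboxylic acid on this carbonyl carbon.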